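The compounds below may be only part of what the source reports. "The series", "measured", "known", "first", "only" and "open" are said of these compounds alone.

Compound 3 `Cc1nc(-c2ccccc2)sc1C(=O)CSc1nc(-c2ccccc2)c(C#N)c(=O)[nH]1` has the lowest of the three numbers in a functional assay on U-87MG ATCC cells for antiproliferative activity against U-87 MG (Homo sapiens), read by MTT assay, with a stated time of 48 h, tested at 10 uM (on this read-out lower numbers stand for a stronger effect and higher numbers for a weaker effect at the one concentration tested), where compound 3 gives 87.5%, though that lies within the scatter of the other two. Compound 1 `COc1ccc(-c2nc(SCC(=O)c3sc(-c4ccccc4)nc3C)[nH]c(=O)c2C#N)cc1` gives 90.4% and compound 2 `COc1cccc(-c2nc(SCC(=O)c3sc(-c4ccccc4)nc3C)[nH]c(=O)c2C#N)c1` gives 90.2% in this assay, and the step of a number 0.2 percentage points lower from compound 1 to compound 2 (within the scatter) separates nothing. Compound 4 `COc1ccc(-c2nc(SCC(=O)c3sc(-c4ccccc4)nc3C)[nH]c(=O)c2C#N)cc1OC` differs from compound 3 in one place: 3,4-dimethoxyphenyl in place of phenyl on an aromatic carbon. Within the data shown here, the steps that bear on this are the removals of a single methoxy group, which gave a number 2.9 percentage points lower from compound 1 to compound 3 (within the scatter) and a number 2.7 percentage points lower from compound 2 to compound 3 (within the scatter), both within the scatter. Entering two methoxy groups is therefore expected to give a step of a number 1.5 percentage points higher from compound 3 to compound 4 (within the scatter), none beyond the scatter. Compound 4 is estimated at 89%, with a range from 78% to 100%.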

Compound 4, a percentage reported as activity, at one concentration (the size of the read-out at that concentration, not a potency): 69.8%
For compound 4 the middle estimate is 19.2 percentage points above the measured one, and the stated range ends above it.
By their numbers in this assay, from the lowest: compound 4; then compounds 3, 2 and 1 (each within the scatter of the next).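

In this assay, the position ortho to a cyano group proves responsive after all: 3,4-dimethoxyphenyl gives a clearly stronger effect than phenyl (a number 17.7 percentage points lower from compound 3 to compound 4 (beyond the scatter)). A second methoxy group also separates compound 4 from both single-methoxy compounds (a number 20.4 percentage points lower from compound 2 to compound 4 (beyond the scatter); a number 20.6 percentage points lower from compound 1 to compound 4 (beyond the scatter)). The effect of a methoxy group therefore depends on the substitution already present on that ring: the same change on two cores in this assay, a number 2.9 percentage points lower (within the scatter) from compound 1 to compound 3 and a number 20.4 percentage points higher (beyond the scatter) from compound 4 to compound 2, 23.3 percentage points apart, beyond the scatter of two such steps.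

As far as these compounds go, whether both methoxy groups are needed, or an amine or a carboxylic acid on that ring would act likewise, remains open. A single concentration also leaves open whether the stronger effect of compound 4 holds at other concentrations.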